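The source may report more compounds than this note shows. Statements on the series, on what has been measured and on what is new or still open speak of the compounds shown alone.

Compound 1, `Cc1ccc(C/N=c2\c(O)c(O)\c2=N/C(C)(C)C)c(C)c1`: 630 nM.
Compound 2, `CC[C@H](C)/N=c1\c(O)c(O)\c1=N/Cc1ccc(C#N)cc1`: 2200 nM.
Compound 3, `CCc1cc(C#N)ccc1C/N=c1\c(O)c(O)\c1=N/[C@H](C)C(C)(C)C`: 2000 nM.

These three numbers come from a functional assay for inhibition, with Rattus norvegicus as the target; a higher number here means a weaker inhibitor, a lower number a stronger inhibitor. Compound 2 stands at the highest of them, though its gap to compound 3 lies within the usual scatter; only its gap to compound 1 lies beyond it.

Compound 4, `CCCC/N=c1\c(O)c(O)\c1=N/Cc1ccc(C#N)cc1`, has not been measured. It differs from compound 2 in one place: butyl in place of sec-butyl on a double-bonded nitrogen. Within the data shown here, no measured pair shows this particular change, so the expectation rests on compound 2 alone, and the step in this assay is expected to be small, at most a slight weakening, and likely within the scatter. Compound 4 is therefore estimated at 3000 nM, with a range from 1200 nM to 8000 nM. The expected step is a 1.4-fold higher number from compound 2 to compound 4 (0.13 log units; within the scatter).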

Compound 4, half-maximal inhibitory concentration: > 30000 nM
Compound 4: only a limit was reported; the forecaster's own chance of this, stated with the estimate: 5%; middle value at least 10-fold (1.00 log units) away from the limit.
By their numbers in this assay, from the lowest: compound 1; then compounds 3 and 2 (each within the scatter of the next). At a limit, above all of these: compound 4.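

In this assay, rearranging the same four carbons on the double-bonded nitrogen, with butyl in place of sec-butyl, gives an at least 13-fold higher number from compound 2 to compound 4 (1.13 log units; beyond the scatter). Among these compounds, the atoms are unchanged, so how they are joined is enough to produce a large step at this position, which the earlier compounds could not show. Compound 4 is reported only as a limit, so the true size of the step stays unknown: the limit of > 30000 nM in this assay, at which 1 of the 4 values shown sits.

The compounds shown leave open whether the branch or the defined stereocentre of sec-butyl matters more. From the compounds shown here alone, how an isopropyl, isobutyl or pentyl group would behave at this nitrogen also remains open.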